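Sulfonamide series: solubility notes toward compound 3

This account rests on a few compounds, and the source may have more. Where it says the series, first, only, none or still open, it means among the compounds named here.

Two members of the series have been measured in a physicochemical assay for solubility; on this read-out higher numbers stand for higher solubility and lower numbers for lower solubility. Compound 1 `O=C(c1ccc(C(F)(F)F)cc1)N1CCC(NS(=O)(=O)c2cc(S(=O)(=O)c3ccccc3)ccc2C(F)(F)F)CC1` gives 6300 nM in this assay, and compound 2 `CN(C)c1ccc(C(=O)N2CCC(NS(=O)(=O)c3cc(S(=O)(=O)c4ccccc4)ccc3C(F)(F)F)CC2)cc1` gives 50000 nM. Among the compounds with values here, the one step available, a 7.9-fold higher number from compound 1 to compound 2 (0.90 log units; beyond the scatter), is a change on an aromatic carbon of the group attached to the ring amide. Within the data shown here, compound 2 thus holds the highest of the two numbers so far, with compound 1 as its nearest neighbour at a lower number.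

Compound 3 `N#Cc1cccc(S(=O)(=O)N2CCC(NS(=O)(=O)c3cc(S(=O)(=O)c4ccccc4)ccc3C(F)(F)F)CC2)c1` is not yet measured. It differs from compound 2 by (3-cyanophenyl)sulfonyl in place of (4-(dimethylamino)phenyl)carbonyl on an amine nitrogen in a ring. This change is of a different kind from the measured step: it swaps the whole group on the amine nitrogen in the ring, and the dimethylamino group that set compound 2 apart from compound 1 leaves with it. Among the measured compounds shown here, no measured step bears directly on this exchange, so the direction is uncertain; the only guide is that compound 1, which also lacks the dimethylamino group, sits at 6300 nM.

Compound 3 is therefore estimated at 12000 nM, with a range of 3000 nM to 50000 nM, which would mean an expected step of a 4.2-fold lower number from compound 2 to compound 3 (0.62 log units; beyond the scatter).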

Compound 3, solubility: 6300 nM
For compound 3 the middle estimate is 1.9-fold (0.28 log units) above the measured one, and the stated range covers the measured number.
By their numbers in this assay, from the lowest: compounds 1 and 3 (each within the scatter of the next); then compound 2.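

In this assay, the whole group on the amine nitrogen in a ring can be exchanged with a clear shift: (3-cyanophenyl)sulfonyl in place of (4-(dimethylamino)phenyl)carbonyl gives a 7.9-fold lower number from compound 2 to compound 3 (0.90 log units; beyond the scatter), a step of the same printed size as a 7.9-fold higher number from compound 1 to compound 2 (0.90 log units; beyond the scatter) but in the opposite direction. Set against (4-(trifluoromethyl)phenyl)carbonyl, the same group gives no change at the digits printed from compound 1 to compound 3 (within the scatter), so two quite different groups at this position cannot be told apart on this read-out, and among the three compounds only compound 2 stands apart. Nothing on hand accounts for either step.

The compounds shown leave open how much of the step from compound 2 belongs to the sulfonyl or carbonyl link and how much to the group on the aromatic ring, as both differ at once in compound 3. They also leave open where a carboxylic acid or a longer chain ending in an amine on that aromatic ring would fall in this assay relative to compound 2.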